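The source may report more compounds than this note shows. Statements on the series, on what has been measured and on what is new or still open speak of the compounds shown alone.

Measured so far:
Compound 1 `CC(=O)Nc1ccc(-n2nncc2CN2C(=O)C3(C(C#N)=C(N)Oc4c(N)cc5nc6ccccc6nc5c43)c3ccccc32)cc1`: in a functional assay on MCF7 cells (Homo sapiens) for antiproliferative activity, read by MTT assay, with a stated time of 48 h (a higher number here means a weaker inhibitor, a lower number a stronger inhibitor), compound 1 reaches only the limit > 50000 nM.
Compound 2 `N#CC1=C(N)Oc2c(N)cc3nc4ccccc4nc3c2C12C(=O)N(Cc1cnnn1-c1ccc([N+](=O)[O-])cc1[N+](=O)[O-])c1ccccc12`: in this assay compound 2 gives 20900 nM.

Compound 2 holds the only number shown. The other value is a limit (the limit of > 50000 nM in this assay, at which 1 of the 2 values shown sits). Compound 3 `N#CC1=C(N)Oc2c(N)cc3nc4ccccc4nc3c2C12C(=O)N(Cc1cnnn1-c1ccc(Cl)cc1[N+](=O)[O-])c1ccccc12` differs from compound 2 by chloro in place of nitro on an aromatic carbon. Among the compounds with values here, only one measured step bears on this: an at least 2.3-fold lower number from compound 1 to compound 2 (0.37 log units; beyond the scatter), and the limit on compound 1 leaves its true size open. That step swapped the whole aryl group, whereas here one nitro is exchanged for chloro, so a small shift toward a higher number is expected, a 1.4-fold higher number from compound 2 to compound 3 (0.16 log units; within the scatter). Compound 3 is estimated at 30000 nM, between 10000 nM and 100000 nM.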

Compound 3, half-maximal inhibitory concentration: > 50000 nM
Compound 3 gave a limit, no number; the forecaster's own chance of this, stated with the estimate: 35%; at least 1.6-fold (0.22 log units) between middle value and limit.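

In this assay this single exchange of nitro for chloro, on the carbon para to a large group, gives an at least 2.3-fold higher number from compound 2 to compound 3 (0.37 log units; beyond the scatter) and so shows that this one position alone can move the number, which the earlier swap of the whole aryl group could not separate. The step from compound 1 to compound 3 cannot be read. Compound 3 gives only a limit, so the full size of the exchange stays open: the limit of > 50000 nM in this assay, at which 2 of the 3 values shown sit.

As far as these compounds go, whether an amine, a methoxy group or a plain hydrogen at this position would keep the number of compound 2 remains open.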